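This account rests on a few compounds, and the source may have more. Where it says the series, first, only, none or still open, it means among the compounds named here.

Three compounds of the shared core have been run in an assay on HEK293 cells for displacement of a labelled ligand from 5-hydroxytryptamine receptor 7 (Rattus norvegicus), with a stated time of 60 min; a higher number here means a weaker inhibitor, a lower number a stronger inhibitor. Compound 1 `FC(F)(F)Oc1ccc(-c2cn(Cc3ccccc3)c3c2CNCC3)cc1` gives 10000 nM, compound 2 `Clc1ccc(-c2cn(Cc3ccccc3)c3c2CNCC3)cc1Cl` gives 4470 nM, and compound 3 `CC(C)(C)c1ccc(-c2cn(Cc3ccccc3)c3c2CNCC3)cc1` gives 10000 nM. Compound 2 stands lowest of the three, beyond the scatter from both others. For the measured compounds named here, the only measured step, no change at the digits printed from compound 1 to compound 3 (within the scatter), exchanges one group on an aromatic carbon without moving the number. Compound 4 `Clc1cccc(-c2cn(Cc3ccccc3)c3c2CNCC3)c1` differs from compound 2 by hydrogen in place of chloro on an aromatic carbon. Going by the values given here, no measured step removes a chloro, so no measured step bears directly on this change; the one step seen so far was flat in this assay. A modest rise in the number is expected, and compound 4 is estimated at 7000 nM, from 3000 nM to 15000 nM. The expected step is a 1.6-fold higher number from compound 2 to compound 4 (0.19 log units; within the scatter).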

Compound 4, inhibition constant: 10000 nM
Estimate against measurement, compound 4: 1.4-fold (0.15 log units) below, and the stated range covers the measured number.
By their numbers in this assay, from the lowest: compound 2; then compounds 1, 3 and 4 (each within the scatter of the next).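

In this assay, the change from 3,4-dichlorophenyl to 3-chlorophenyl gives a 2.2-fold higher number from compound 2 to compound 4 (0.35 log units; beyond the scatter), the only step shown so far that lies beyond the scatter. The chloro para to the large group therefore counts in this series, and hydrogen in its place loses the lower number seen for compound 2. Nothing available explains this step.

As far as these compounds go, whether a methoxy group or an amine on this carbon would keep the number of compound 2 stays open. So does the outcome of replacing the remaining chloro with hydrogen.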